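Naphthalenyl replacing cyclohexylmethyl on the quinoline-like core: cytotoxicity outlook

The source may hold more compounds than are shown below. What is called first, only, known or untested is meant among the compounds shown, and "the series" means these compounds.

For the measured compounds named here, compound 2 `COc1cccc(CNCCCNc2ccnc3cc(CC4CCCCC4)ccc23)c1O` gives the lower of the two numbers so far in an ADME assay on HepG2 cells (Homo sapiens) for cytotoxicity, read by luminescence, CellTiter-Glo and ATP content, with a stated time of 72 h (on this read-out higher numbers stand for an effect only at larger amounts of compound and lower numbers for an effect already at smaller amounts), namely 970 nM, while compound 1 `COc1cccc(CNCCCNc2ccnc3cc(CCc4ccccc4)ccc23)c1O` in this assay gives 6800 nM. Going by the values given here, the only step available, a 7.0-fold lower number from compound 1 to compound 2 (0.85 log units; beyond the scatter), exchanged an aromatic ring for a saturated one on a chain carbon. Compound 3 `COc1cccc(CNCCCNc2ccnc3cc(-c4cccc5ccccc45)ccc23)c1O` differs from compound 2 by naphthalen-1-yl in place of cyclohexylmethyl on an aromatic carbon. Among the compounds with values here, this change reverses the aromatic-for-saturated direction of the one step seen and at the same time removes the linking chain carbon and adds a second ring, so the measured step bears on it only loosely. Compound 3 is therefore expected to move back toward a higher number, with a 3.1-fold higher number from compound 2 to compound 3 (0.49 log units; beyond the scatter) as the estimated step, though a result within the scatter of compound 2 cannot be excluded. Compound 3 is estimated at 3000 nM, with a range from 800 nM to 12000 nM.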

Compound 3, half-maximal effective concentration: 2520 nM
The estimate for compound 3 lay 1.2-fold (0.08 log units) above the measured number; the measured number falls inside the stated range.
By their numbers in this assay, from the lowest: compound 2; then compound 3; then compound 1.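

At this position on the shared core, naphthalen-1-yl gives in this assay a result that falls between the two earlier compounds: a 2.6-fold higher number from compound 2 to compound 3 (0.41 log units; beyond the scatter) places it above the cyclohexylmethyl compound, while a 2.7-fold lower number from compound 1 to compound 3 (0.43 log units; beyond the scatter) places it below the phenethyl compound. Both compounds with aromatic groups therefore carry higher numbers than the one with a saturated ring, and none of the three goes against this. The order also shows that these aromatic groups are not equivalent, as naphthalen-1-yl, attached directly to the aromatic carbon, and phenethyl differ beyond the scatter.

Because the ring type, ring count and linking chain all change together in these steps, their separate contributions stay unresolved. From the compounds shown here alone, it also remains open how directly attached cyclohexyl or phenyl, a longer chain, an amine or a carboxylic acid would read at this aromatic carbon. No evidence on the origin of these differences is available.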